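Half-maximal cytotoxicity on HeLa cells: compound 3 to compound 4

This account rests on a few compounds, and the source may have more. Where it says the series, first, only, none or still open, it means among the compounds named here.

Compound 3 `COc1nc(-c2ccccc2F)ccc1[C@@H](c1ccccc1)[C@@](O)(CCN(C)C)c1cccc2ccccc12` has no number in a toxicity assay on HeLa cells (Homo sapiens) for cytotoxicity; on this read-out higher numbers stand for lower toxicity in this test and lower numbers for higher toxicity in this test; its entry reads "nd" (no result reported), so its place among the values shown is open. The values measured on this core come from two neighbors. Compound 1 `COc1nc(-c2ccc(Cl)cc2)ccc1[C@@H](c1ccccc1)[C@@](O)(CCN(C)C)c1cccc2ccccc12` gives only a limit of the assay, > 64 ug/mL, in this assay. Compound 2 `COc1nc(-c2cnsc2)ccc1[C@@H](c1ccccc1)[C@@](O)(CCN(C)C)c1cccc2ccccc12` gives 28.8 ug/mL in this assay. Between them stands an at least 2.2-fold lower number from compound 1 to compound 2 (0.34 log units; beyond the scatter), which replaces the 4-chlorophenyl by a 1,2-thiazol-4-yl.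

Compound 4 `COc1nc(-c2ccc(C(F)(F)F)cc2)ccc1[C@@H](c1ccccc1)[C@@](O)(CCN(C)C)c1cccc2ccccc12` differs from compound 3 by 4-(trifluoromethyl)phenyl in place of 2-fluorophenyl on an aromatic carbon. For the measured compounds named here, no measured step carries this change, and no step starts from compound 3, so the direction and size of the move from compound 3 to compound 4 in this assay cannot be read from the measured steps. Going by the values given here, the only value for a compound bearing a phenyl with a single ring substituent on the same position is the limit of compound 1.

Compound 4 is therefore expected to lie near 60 ug/mL in this assay, with a range from 25 ug/mL to 130 ug/mL, because the limit of > 64 ug/mL in this assay, at which 1 of the 3 values shown sits, suggests that a result at the limit is likely again.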

Compound 4, half-maximal cytotoxic concentration: > 64 ug/mL
Compound 4 ended at the assay's limit (the forecaster's own chance of this, stated with the estimate: 60%); at least 1.0-fold (0.02 log units) between middle value and limit.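

Replacing the 1,2-thiazol-4-yl at this position by 4-(trifluoromethyl)phenyl gives an at least 2.2-fold higher number from compound 2 to compound 4 (0.34 log units; beyond the scatter), so in this assay a second substituted phenyl, and not 4-chlorophenyl alone, stands apart from the 1,2-thiazol-4-yl. Compound 4 gives > 64 ug/mL, which is a limit of the assay and not a number. Compound 1 also sits at this limit, so the change from chloro to trifluoromethyl on the phenyl cannot be read, and the limit recurs among the values shown: the limit of > 64 ug/mL in this assay, at which 2 of the 4 values shown sit.

From the compounds shown here alone, compound 3 still has no result, so it remains open whether 2-fluorophenyl sits with the two substituted phenyls at the limit or with the 1,2-thiazol-4-yl, and how far compound 1 and compound 4 lie beyond the limit is also unknown. Equally open, going by these compounds, is whether a phenyl carrying an amine or a carboxylic acid at the same place would give a readable number in this assay, as compound 2 does with 28.8 ug/mL.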